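The compounds below may be only part of what the source reports. "The series", "measured", "known", "first", "only" and "open" are said of these compounds alone.

Compound 1 `C=C[C@@](C)(CC[C@H]1C(C)=CC[C@H]2C(C)(C)CCC[C@]12C)O[C@@H]1O[C@H](C)[C@H](O)[C@H](O)[C@H]1O` is the reference point of this short series. In a functional assay on SK-MEL-2 cells (Homo sapiens) for cytotoxicity, read by sulforhodamine B assay (a lower number here means that less compound is needed, a higher number that more compound is needed for the effect), compound 1 gives 3.5 ug/mL, the highest of the two values that are actual numbers. Compound 3 `C=C[C@@](C)(CC[C@H]1C(C)=CC[C@H]2C(C)(C)CCC[C@]12C)O[C@@H]1O[C@H](C)[C@H](OC(C)=O)[C@H](O)[C@H]1O` is its nearest neighbour, and in this assay compound 3 gives 3.4 ug/mL. Compound 2 `C=C[C@](C)(O)CC[C@H]1C(=C)[C@H](O)C[C@H]2C(C)(C)CCC[C@]12C` is the third member of the set. In this assay compound 2 reaches only > 5 ug/mL, which is a limit of the assay rather than a number; the sole such limit here, (the limit of > 5 ug/mL in this assay, at which 1 of the 3 values shown sits), belongs to compound 2. Going by the values given here, the only measured step that runs in one place, a 1.0-fold lower number from compound 1 to compound 3 (0.01 log units; within the scatter), involves an acetyl in place of hydrogen on an oxygen on a saturated carbon and leaves the read-out essentially unchanged.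

Compound 4 `C=C[C@@](C)(CC[C@H]1C(C)=CC[C@H]2C(C)(C)CCC[C@]12C)O[C@@H]1O[C@H](C)[C@H](O)[C@H](OC(C)=O)[C@H]1O` differs from compound 1 by acetyl in place of hydrogen on an oxygen on a saturated carbon. This is the same kind of change as the measured step, placed on a different oxygen of the same sugar-bearing part, so the outcome is expected to be similar: little or no shift beyond the scatter. The step expected in this assay is no change at the digits printed from compound 1 to compound 4 (within the scatter), no larger than the scatter. Compound 4 is therefore expected to give about 3.5 ug/mL, with a range from 1.8 ug/mL to 7 ug/mL.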

Compound 4, concentration for half-maximal effect: 3.5 ug/mL
The estimate for compound 4 equals the measured number at the digits printed; the measured number falls inside the stated range.
By their numbers in this assay, from the lowest: compounds 3, 1 and 4 (each within the scatter of the next). At a limit, above all of these: compound 2.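

In this assay, the step of no change at the digits printed from compound 1 to compound 4 (within the scatter) shows that hydroxy to acetoxy at this second oxygen on a saturated carbon leaves the read-out where it was. Going by these compounds alone, until now, the only reading of this change was the step of a 1.0-fold lower number from compound 1 to compound 3 (0.01 log units; within the scatter), at a single oxygen, so it could not be said whether that flat result held beyond that one place. With both steps within the scatter, the change has now been read at two oxygens of the sugar of compound 1 and moved the number at neither, though nothing here gives a cause for this.

The compounds shown leave open whether an acetyl on both of these oxygens together would behave the same way. They also leave open whether a larger benzoyl ester, or an amine in place of the hydroxy, would shift the number at either oxygen.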